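The source may report more compounds than this note shows. Statements on the series, on what has been measured and on what is new or still open speak of the compounds shown alone.

Three compounds sharing one core show how much the group on its oxygen matters. In a functional assay for inhibition, with Sus scrofa as the target (on this read-out lower numbers stand for stronger inhibition and higher numbers for weaker inhibition), compound 1 (`CC1(C)Oc2ccc(C#N)cc2[C@@H](Oc2ccccn2)[C@]1(C)O`) gives 6000 nM. Compound 2 (`CC1(C)Oc2ccc(C#N)cc2[C@@H](On2ccccc2=O)[C@]1(C)O`) reads > 100000 nM, which is a limit of the assay and not a number. Compound 3 (`CC1(C)Oc2ccc(C#N)cc2[C@@H](Oc2ccc(=O)[nH]n2)[C@]1(C)O`) gives 6 nM, the lowest number of the three and so the strongest inhibition seen here.

Compound 4 (`CC1(C)Oc2ccc(C#N)cc2[C@H](Oc2ccc(=O)[nH]n2)[C@@]1(C)O`) is the mirror image of compound 3: the two compounds have the same atoms and bonds and differ only in configuration as drawn: 2 of 2 stereo elements differ (all stereocentres are inverted: mirror images); a stereocentre at a saturated ring carbon is drawn R in compound 3 and S in compound 4; a stereocentre at a saturated ring carbon is drawn S in compound 3 and R in compound 4. Among the measured compounds shown here, no measured pair in this set is a mirror-image pair, so no measured step gives the size of this change directly. The nearest guide is how strongly this assay reacts to changes in the group on that oxygen. The steps are large: an at least 16-fold higher number from compound 1 to compound 2 (1.22 log units; beyond the scatter), a 1000-fold lower number from compound 1 to compound 3 (3.00 log units; beyond the scatter) and an at least 16000-fold lower number from compound 2 to compound 3 (4.22 log units; beyond the scatter), all beyond the scatter. The low number of compound 3, at 6 nM, therefore looks tied closely to its exact structure, and a full inversion of both stereocentres seems unlikely to preserve it.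

A large move towards weaker inhibition is expected, estimated as a 130-fold higher number from compound 3 to compound 4 (2.12 log units; beyond the scatter). For compound 4 the expected value is 800 nM, with an estimated range of 50 nM to 30000 nM.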

Compound 4, half-maximal inhibitory concentration: 100000 nM
Estimate against measurement, compound 4: 130-fold (2.10 log units) below, and the stated range ends below it.
By their numbers in this assay, from the lowest: compound 3; then compound 1; then compound 4.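

The earlier compounds shown here changed the group on the oxygen, whereas here that group stays and only the spatial arrangement changes. In this assay this alone gives a 17000-fold higher number from compound 3 to compound 4 (4.22 log units; beyond the scatter), and the cause can lie nowhere but in configuration: the fact that compounds 3 and 4 differ only in the configuration as drawn. The group on the oxygen in compound 3 is therefore not enough by itself, since its low number appears only with both stereocentres at the saturated ring carbons drawn as in compound 3. The reading for compound 4 also stands at the same figure as the limit seen in this set, so the true size of the step may be larger than the number shows: the limit of > 100000 nM in this assay, at which 1 of the 4 values shown sits.

Both stereocentres invert together in this pair, so the compounds shown cannot tell whether one of them accounts for most of the change or both contribute, as no compound with only one inverted centre is among them. They also leave open whether configuration matters as much with another group on that oxygen, such as a carboxylic acid or an amine on a longer chain.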